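This account rests on a few compounds, and the source may have more. Where it says the series, first, only, none or still open, it means among the compounds named here.

Measured so far in a functional assay on MGC-803 cells (Homo sapiens) for inhibition, read by MTT assay, with a stated time of 48 h; a lower number here means a stronger inhibitor, a higher number a weaker inhibitor:
compound 1, `COc1ccc(CN(C(=O)CCl)c2cc(OC)c(OC)c(OC)c2)cc1O`: 84 nM
compound 2, `C/C=C/C(=O)N(Cc1ccc(OC)c(Br)c1)c1cc(OC)c(OC)c(OC)c1`: 6430 nM
compound 3, `COc1cc(NCc2cccc(O)c2)cc(OC)c1OC`: 57600 nM

Compound 1 stands lowest of the three numbers. Compound 2 lies nearest, at 6430 nM, a gap beyond the scatter. Compound 3 lies furthest, at 57600 nM, also beyond the scatter.

Compound 4, `COc1ccc(CN(C(=O)CBr)c2cc(OC)c(OC)c(OC)c2)cc1O`, is not yet measured. It differs from compound 1 in one place: bromo in place of chloro on a saturated chain carbon bound to a carbonyl carbon. Among the measured compounds shown here, no measured pair shows this change, so no step size is known from the data. The step from compound 1 to compound 4 is expected to be small, either none beyond the scatter or a modest move toward a lower number, estimated as a 1.4-fold lower number from compound 1 to compound 4 (0.15 log units; within the scatter). Compound 4 is therefore expected near 60 nM, in the range 20 nM to 200 nM. The anchor for this expectation is compound 1 at 84 nM.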

Compound 4, half-maximal inhibitory concentration: 140 nM
Estimate against measurement, compound 4: 2.3-fold (0.37 log units) below; measured number inside the range.
By their numbers in this assay, from the lowest: compounds 1 and 4 (each within the scatter of the next); then compound 2; then compound 3.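

In this assay, bromo in place of chloro on a saturated chain carbon bound to a carbonyl carbon gives a 1.7-fold higher number from compound 1 to compound 4 (0.22 log units; within the scatter) and so does not separate the two halogens at this position. Among the compounds shown here, this is the first pair that differs in one place, and it gives a first step size for this position. No available evidence explains this result. Going by these compounds, whether this chain carbon needs a halogen at all remains open, as does how an amine, a hydroxyl or a longer chain in that place would read.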